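The compounds below may be only part of what the source reports. "The series", "measured", "known", "first", "only" and "open" are said of these compounds alone.

Working notes, series of bis(arylidene)piperidinones bearing a triazole arm.

Compound 2 `O=C1/C(=C/c2ccccc2F)CN(Cc2cn(Cc3cccc(Cl)c3)nn2)C/C1=C\c1ccccc1F` gives 4300 nM in a functional assay on DU-145 cells (Homo sapiens) for cytotoxicity, read by MTT assay, with a stated time of 24 h; a lower number here means a stronger inhibitor, a higher number a weaker inhibitor. Compound 1 `O=C1/C(=C/c2ccccc2F)CN(Cc2cn(Cc3ccccc3F)nn2)C/C1=C\c1ccccc1F` differs from compound 2 by 2-fluorophenyl in place of 3-chlorophenyl on a saturated chain carbon bound to an aromatic nitrogen; in this assay compound 1 gives 10600 nM, so the change reads as a 2.5-fold higher number from compound 2 to compound 1 (0.39 log units; beyond the scatter), a step toward a weaker inhibitor.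

Compound 3 `Cc1ccc(/C=C2\CN(C(=S)SCc3cn(Cc4cccc(Cl)c4)nn3)C/C(=C\c3ccc(C)cc3)C2=O)cc1` carries the same change-bearing arm on a different core; how its core differs from that of compound 2 is not broken down here. For compound 3 this assay returns only a limit, > 80000 nM, not a number. This is the limit of > 80000 nM in this assay, at which 1 of the 3 values shown sits.

Compound 4 `Cc1ccc(/C=C2\CN(C(=S)SCc3cn(Cc4ccccc4F)nn3)C/C(=C\c3ccc(C)cc3)C2=O)cc1` is compound 3 with 2-fluorophenyl in place of 3-chlorophenyl on a saturated chain carbon bound to an aromatic nitrogen, the same change already made from compound 2 to compound 1, at a place worded identically. Since the earlier step was a 2.5-fold higher number from compound 2 to compound 1 (0.39 log units; beyond the scatter), the expectation for compound 4 in this assay is a step of about the same direction, a step that the limit leaves unreadable from compound 3 to compound 4, resting on compound 1 at 10600 nM against compound 2 at 4300 nM. Compound 4 is therefore expected near 150000 nM, most likely again reported only as a limit, within 60000 nM to 400000 nM.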

Compound 4, half-maximal inhibitory concentration: 80000 nM
Estimate against measurement, compound 4: 1.9-fold (0.27 log units) above; low and high end bracket the measured number.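

Compound 3 stands at a limit of this assay, > 80000 nM, which is a limit and not a number. The new step is a number no higher from compound 3 to compound 4 (the limit leaves the size open) and its size cannot be read. Set side by side, the change from 3-chlorobenzyl to 2-fluorobenzyl on the two cores reads: the same change on two cores in this assay, a 2.5-fold higher number (0.39 log units; beyond the scatter) from compound 2 to compound 1 and a number no higher (the limit leaves the size open) from compound 3 to compound 4; the limit leaves it open whether they differ

Among these compounds, the one readable step remains a 2.5-fold higher number from compound 2 to compound 1 (0.39 log units; beyond the scatter); it shows what this change does on the core of compound 2, and it does not show whether the same size or direction carries over to the core of compound 4, where the result fits either a matching step or a different one.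

Open, as far as these compounds go, is whether the step could be read on the core of compound 4 with a partner whose value is a number rather than a limit. Also open, from the compounds shown here alone, is whether a benzyl arm carrying another group, such as a methoxy group, an amine or a carboxylic acid, would follow the same direction on either core.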